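The source may hold more compounds than are shown below. What is called first, only, known or untested is meant among the compounds shown, and "the series" means these compounds.

Compound 1 `N#CCCCn1c(Cn2c(=O)n(-c3ccncn3)c3ccncc32)cc2cc(Cl)ccc21` was examined in an ADME assay on HeLa cells (Homo sapiens) for cytotoxicity, read by ATP content, with a stated time of 3 days (a lower number here means that less compound is tolerated, a higher number that more compound is tolerated), and gave > 50000 nM, which is a limit of the assay rather than a number. Compound 2 `CS(=O)(=O)CCCn1c(Cn2c(=O)n(C3CC3)c3ccncc32)nc2nc(Cl)ccc21` likewise gave > 50000 nM in this assay, again a limit. Both measured values thus sit at the limit of > 50000 nM in this assay, at which 2 of the 2 values shown sit, so compound 1 stands at the top of what has been observed. Compound 3 `N#CCCCn1c(Cn2c(=O)n(-c3ccncc3F)c3ccncc32)cc2cc(Cl)ccc21` has not yet been measured in this assay; it differs from compound 1 by 3-fluoropyridin-4-yl in place of pyrimidin-4-yl on an aromatic nitrogen. For the measured compounds named here, with no measured step to draw on, no change beyond the scatter is expected: a number no higher from compound 1 to compound 3 (the limit leaves the size open). Compound 3 is therefore estimated to give 50000 nM, with a range from 25000 nM to 100000 nM.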

Compound 3, half-maximal cytotoxic concentration: > 50000 nM
Compound 3: no number, only a limit; the forecaster's own chance of this, stated with the estimate: 75%; the middle value lies on the limit itself.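

In this assay, for the compounds shown here, compound 3 gives > 50000 nM, a limit of the assay and not a number; with compound 1 also at a limit, no step from compound 1 to compound 3 can be read. The compounds shown leave open the concentration at which any of them would reach half-maximal cytotoxicity: the limit of > 50000 nM in this assay, at which 3 of the 3 values shown sit.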